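Swapping the aryl tail of a uridine triphosphate agonist

The compounds below may be only part of what the source reports. "The series", "measured", "known", "first", "only" and "open" are said of these compounds alone.

Measured compounds:
Compound 1, `O=c1[nH]/c(=N\OCCCc2cccc(F)c2)ccn1[C@@H]1O[C@H](COP(=O)(O)OP(=O)(O)OP(=O)(O)O)[C@@H](O)[C@H]1O` — 190 nM
Compound 2, `O=c1[nH]/c(=N\OCCCc2ccc([N+](=O)[O-])cc2)ccn1[C@@H]1O[C@H](COP(=O)(O)OP(=O)(O)OP(=O)(O)O)[C@@H](O)[C@H]1O` — 458 nM
Compound 3, `COc1ccc(CCCO/N=c2/ccn([C@@H]3O[C@H](COP(=O)(O)OP(=O)(O)OP(=O)(O)O)[C@@H](O)[C@H]3O)c(=O)[nH]2)cc1` — 47 nM

Three compounds share one triphosphate nucleoside core and differ only in the aromatic ring at the end of the side chain. In a functional assay on 1321-N1 cells for agonist activity at P2Y purinoceptor 2 (Homo sapiens), read by scintillation counting and inositol phosphate accumulation (a lower number here means that less compound is needed, a higher number that more compound is needed for the effect), compound 3 gives the lowest number of the three, so the least of it is needed for the effect. The step of a 4.0-fold lower number from compound 1 to compound 3 (0.61 log units; beyond the scatter) and the step of a 9.7-fold lower number from compound 2 to compound 3 (0.99 log units; beyond the scatter) both favour compound 3, while a 2.4-fold higher number from compound 1 to compound 2 (0.38 log units; beyond the scatter) goes the other way.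

Compound 4, `O=c1[nH]/c(=N\OCCCc2ccncc2)ccn1[C@@H]1O[C@H](COP(=O)(O)OP(=O)(O)OP(=O)(O)O)[C@@H](O)[C@H]1O`, is not yet measured. It differs from compound 3 by pyridin-4-yl in place of 4-methoxyphenyl on a saturated chain carbon, three bonds along the chain from an oxygen on an unsaturated carbon. For the measured compounds named here, no measured step exchanges the whole ring for one containing nitrogen, so the measured steps bear on it only loosely: every change away from the 4-methoxyphenyl tail so far has given a higher number in this assay, by a 4.0-fold lower number from compound 1 to compound 3 (0.61 log units; beyond the scatter) and a 9.7-fold lower number from compound 2 to compound 3 (0.99 log units; beyond the scatter) read in reverse. A modest rise is therefore expected, of about a 3.2-fold higher number from compound 3 to compound 4 (0.50 log units; beyond the scatter), with the outcome uncertain in size. For compound 4 the estimate is 150 nM, expected to fall between 50 nM and 450 nM.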

Compound 4, half-maximal effective concentration: 285 nM
Estimate against measurement, compound 4: 1.9-fold (0.28 log units) below; the range from low to high includes it.
By their numbers in this assay, from the lowest: compound 3; then compounds 1, 4 and 2 (each within the scatter of the next, the first and the last beyond it).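

Putting pyridin-4-yl at the end of the chain shows that this position accepts a ring containing nitrogen and still gives agonist activity in this assay, though at a cost against the 4-methoxyphenyl tail (a 6.1-fold higher number from compound 3 to compound 4 (0.78 log units; beyond the scatter)). Compound 3 therefore keeps the lowest number, now beyond the scatter of all three other tails. Compound 4 cannot be ordered against either remaining tail (a 1.6-fold lower number from compound 2 to compound 4 (0.21 log units; within the scatter); a 1.5-fold higher number from compound 1 to compound 4 (0.18 log units; within the scatter)), even though compound 1 and compound 2 lie beyond the scatter of each other, so the new ring falls within reach of both and gives no sharper ranking. Nothing available here accounts for why these tails sit where they do.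

The compounds shown leave open whether the advantage of compound 3 belongs to the methoxy group itself, which a 4-hydroxyphenyl or 4-ethoxyphenyl tail on the same chain could test. They also leave open whether the place of the ring nitrogen matters, as pyridin-3-yl or pyridin-2-yl would show, and whether a longer chain would shift these numbers.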